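A few compounds are considered here, and "the series" means these few. Any claim that something is new, unique, unknown or untested is made for them only; others in the source may bear on it.

Two compounds share one core here: compound 1, `CCCCCCc1cc2cn([C@H]3C[C@H](O)[C@@H](CO)O3)c(=O)nc2s1`, and compound 2, `CCCCCCCCCCc1cc2cn([C@H]3C[C@H](O)[C@@H](CO)O3)c(=O)nc2s1`. In a functional assay on HEL cells (Homo sapiens) for cytotoxicity, read by microscopy (on this read-out higher numbers stand for lower toxicity in this test and lower numbers for higher toxicity in this test), compound 1 gives 125000 nM, and compound 2 gives 20000 nM, the lower of the two numbers. Going by the values given here, the single step that separates them, a 6.3-fold lower number from compound 1 to compound 2 (0.80 log units; beyond the scatter), consisted of adding butyl to the chain. Compound 3, `CCCCCCCCCc1cc2cn([C@H]3C[C@H](O)[C@@H](CO)O3)c(=O)nc2s1`, differs from compound 2 by hydrogen in place of methyl on a saturated chain carbon, nine bonds along the chain from an aromatic carbon. Among the compounds with values here, only that one step bears on the change, and it ran in the opposite sense: lengthening the chain lowered the number, so trimming it by one carbon is expected to raise it slightly, perhaps within the scatter. Compound 3 is estimated at 30000 nM, within 12000 nM to 80000 nM, a step of a 1.5-fold higher number from compound 2 to compound 3 (0.18 log units; within the scatter).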

Compound 3, minimum cytotoxic concentration: > 20000 nM
Compound 3 ended at the assay's limit; the forecaster's own chance of this, stated with the estimate: 5%; the middle value does not contradict the limit.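

In this assay compound 3 gives > 20000 nM, which is a limit of the assay and not a number. Taking the methyl off at this place, nine bonds along the chain from an aromatic carbon, gives a number no lower from compound 2 to compound 3 (the limit leaves the size open), so the change in this direction is now seen not to lower the number. How far the number moves with this one carbon cannot be read, nor can the step between compound 1 and compound 3, because the value of compound 3 sits at the limit: the limit of > 20000 nM in this assay, at which 1 of the 3 values shown sits.

The compounds shown leave open whether a longer chain than that of compound 2 would lower the number further. They also leave open what an amine or a carboxylic acid at the chain end would give in this assay.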